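The compounds below may be only part of what the source reports. "The series", "measured", "known", "first", "only" and "open" are said of these compounds alone.

Measured in an ADME assay on microsomes from liver (Canis lupus familiaris) for metabolic stability, read by LC-MS, tested at 1 uM; on this read-out higher numbers stand for fast clearance and lower numbers for slow clearance:
Compound 1 `NCCCOc1ccc([C@H]2CC[C@]3(CC2)OOC2(O3)C3CC4CC(C3)CC2C4)cc1`: < 7 mL.min-1.g-1 (a limit of the assay)
Compound 2 `NC(=O)C1CCN(Cc2ccc([C@H]3CC[C@]4(CC3)OOC3(O4)C4CC5CC(C4)CC3C5)cc2)CC1`: 10 mL.min-1.g-1

Among the measured compounds shown here, compound 2, at 10 mL.min-1.g-1, holds the only true number in this assay so far. Compound 1 gives < 7 mL.min-1.g-1, which is a limit and not a number, so the two cannot be ranked firmly.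

Compound 3 `c1cc([C@H]2CC[C@]3(CC2)OOC2(O3)C3CC4CC(C3)CC2C4)ccc1OCCC1CCNCC1` keeps the shared core but carries 2-(piperidin-4-yl)ethoxy in place of (4-carbamoylpiperidin-1-yl)methyl on an aromatic carbon, para to a large group: 2-(piperidin-4-yl)ethoxy in place of (4-carbamoylpiperidin-1-yl)methyl on an aromatic carbon. For the measured compounds named here, only one measured step bears on this change, an at least 1.4-fold higher number from compound 1 to compound 2 (0.15 log units; that floor lies within the scatter). It removes 3-aminopropoxy and installs the group that compound 3 lacks, and its floor lies within the scatter. Compound 3 resembles compound 1 in joining its side chain through oxygen, so any shift should point weakly towards the limit of compound 1, but the piperidine ring of compound 3 is absent from compound 1, which makes this a loose guide. The expected change is therefore no step beyond the scatter, and the estimate is a 1.1-fold lower number from compound 2 to compound 3 (0.05 log units; within the scatter). For compound 3 the estimated value is 9 mL.min-1.g-1, expected to fall between 4 mL.min-1.g-1 and 20 mL.min-1.g-1.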

Compound 3, intrinsic clearance in microsomes: 16 mL.min-1.g-1
For compound 3 the middle estimate is 1.8-fold (0.25 log units) below the measured one; measured number inside the range.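

In this assay, 2-(piperidin-4-yl)ethoxy in place of (4-carbamoylpiperidin-1-yl)methyl on an aromatic carbon, para to a large group, gives a 1.6-fold higher number from compound 2 to compound 3 (0.20 log units; within the scatter), so this read-out does not separate these two side chains. Among the compounds shown here, the comparison of the two oxygen-linked side chains gives the first step in this set that is beyond the scatter, an at least 2.2-fold higher number from compound 1 to compound 3 (0.35 log units; beyond the scatter), for piperidin-4-yl in place of aminomethyl on a saturated chain carbon, two bonds along the chain from an oxygen on an aromatic ring. That figure is a floor and not the full size of the step, because compound 1 stands at a limit of the assay and not at a number: the limit of < 7 mL.min-1.g-1 in this assay, at which 1 of the 3 values shown sits.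

On these data alone, how far compound 1 lies past its limit remains open, and with it the true size of the step from the aminomethyl end to the piperidin-4-yl end of the chain. Also open, as far as these compounds go, is how a morpholine ring, a carboxylic acid or a longer chain on the same aromatic carbon would read in this assay.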